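This account rests on a few compounds, and the source may have more. Where it says the series, first, only, none or still open, it means among the compounds named here.

In a functional assay on A2780 cells (Homo sapiens) for cytotoxicity, read by MTT assay, with a stated time of 72 h (a lower number here means a stronger inhibitor, a higher number a weaker inhibitor), compound 1 `Nc1ccccc1NC(=O)CCCCCN(CC(=O)NCc1ccccc1)C(=O)c1cccc2ccccc12` gives 22800 nM, compound 2 `Cc1cc(C)cc(C(=O)N(CCCCCC(=O)Nc2ccccc2N)CC(=O)NCc2ccccc2)c1` gives 20900 nM and compound 3 `CN(C)c1ccc(C(=O)N(CCCCCC(=O)Nc2ccccc2N)CC(=O)NCc2ccccc2)cc1` gives 18500 nM. Compound 2 therefore sits within the scatter of both others. Compound 4 `COc1ccc(CNC(=O)CN(CCCCCC(=O)Nc2ccccc2N)C(=O)c2cc(C)cc(C)c2)cc1` differs from compound 2 by methoxy in place of hydrogen on an aromatic carbon, which turns benzyl into 4-methoxybenzyl. The measured steps, a 1.1-fold lower number from compound 1 to compound 2 (0.04 log units; within the scatter), a 1.2-fold lower number from compound 1 to compound 3 (0.09 log units; within the scatter) and a 1.1-fold lower number from compound 2 to compound 3 (0.05 log units; within the scatter), all change the group on a carbonyl carbon, not the benzyl group, so they bear on this change only indirectly. Among the measured compounds shown here, no measured step tests the benzyl group itself. In this assay the expected step is a 1.0-fold lower number from compound 2 to compound 4 (0.02 log units; within the scatter), with no shift beyond the scatter anticipated in either direction. For compound 4 the estimated value is 20000 nM, within an expected range of 10000 nM to 36000 nM.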

Compound 4, half-maximal inhibitory concentration: 24600 nM
Beside the measured number, compound 4's estimate is 1.2-fold (0.09 log units) below it; the measured number falls inside the stated range.
By their numbers in this assay, from the lowest: compounds 3, 2, 1 and 4 (each within the scatter of the next).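

In this assay the benzyl group itself is now tested, and the step of a 1.2-fold higher number from compound 2 to compound 4 (0.07 log units; within the scatter) comes from methoxy in place of hydrogen, para to a large group. Like the changes on the carbonyl carbon, this change on the benzyl ring gives no shift beyond the scatter. No measurement at hand offers an explanation for this result.
On these data alone, whether an amine or a carboxylic acid on the same aromatic carbon would give a step beyond the scatter remains open. So does the effect of a longer chain on the shared core.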